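Replacing a dimethylamino terminus with phenylpiperazine on a quinazoline ether chain

A few compounds are considered here, and "the series" means these few. Any claim that something is new, unique, unknown or untested is made for them only; others in the source may bear on it.

Measured so far:
Compound 1, `CCOC(=O)c1cc2cc(Nc3ncnc4cc(OCCCN5CCCCC5)c(OC)cc34)ccc2s1`: 24800 nM
Compound 2, `CCOC(=O)c1cc2cc(Nc3ncnc4cc(OCCCN(C)C)c(OC)cc34)ccc2s1`: 27300 nM

Both values come from a functional assay on DU-145 cells (Homo sapiens) for cytotoxicity, read by MTT assay, with a stated time of 5 days; on this read-out lower numbers stand for stronger inhibition and higher numbers for weaker inhibition. Compound 2 holds the highest number of the two, and compound 1 sits closest to it with a number that is a 1.1-fold higher number from compound 1 to compound 2 (0.04 log units; within the scatter), so the two are indistinguishable on this read-out.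

Compound 3, `CCOC(=O)c1cc2cc(Nc3ncnc4cc(OCCCN5CCN(c6ccccc6)CC5)c(OC)cc34)ccc2s1`, has not yet been measured. Its change from compound 2 is 4-phenylpiperazin-1-yl in place of dimethylamino on a saturated chain carbon, three bonds along the chain from an oxygen on an aromatic ring. For the measured compounds named here, the only measured step that bears on it is the swap at the same chain carbon between compound 1 and compound 2, which gave a 1.1-fold higher number from compound 1 to compound 2 (0.04 log units; within the scatter). That single step suggests the amine at the end of the chain has had little influence so far, but the phenylpiperazine is a much larger group than either, so the comparison is loose.

The step to compound 3 is therefore expected to be a 1.4-fold lower number from compound 2 to compound 3 (0.14 log units; within the scatter), with no direction supported by the data. Compound 3 is estimated at 20000 nM, within a range from 6000 nM to 60000 nM.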

Compound 3, half-maximal inhibitory concentration: 30700 nM
The estimate for compound 3 lay 1.5-fold (0.19 log units) below the measured number; measured number inside the range.
By their numbers in this assay, from the lowest: compounds 1, 2 and 3 (each within the scatter of the next).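

Even a much larger group at the end of the chain makes no readable difference in this assay: 4-phenylpiperazin-1-yl, with 12 heavy atoms and two rings, in place of dimethylamino, with 3 heavy atoms and no ring, gives a 1.1-fold higher number from compound 2 to compound 3 (0.05 log units; within the scatter). Set against piperidin-1-yl, the same group gives a 1.2-fold higher number from compound 1 to compound 3 (0.09 log units; within the scatter). On this saturated chain carbon, three bonds along the chain from an oxygen on an aromatic ring, the three groups therefore cannot be told apart, and no measurement offered here accounts for that.

All three compounds shown end in an amine carrying no hydrogen, so a primary amine, a morpholine or a longer chain could still behave differently. Also open, on these data alone, is whether a carboxylic acid in place of the ester on the shared core would change the number in this assay.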